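The compounds below may be only part of what the source reports. "The series", "measured", "known", "first", "only" and "open" are said of these compounds alone.

Compound 2, with the structure `O=C(c1cc2ccccc2o1)N1CCC(NCCSC(c2ccc(F)cc2)c2ccc(F)cc2)CC1`, carries a (1-benzofuran-2-yl)carbonyl group on the ring nitrogen of its core. In an assay on membranes from striatum (strain Sprague-Dawley) for displacement of a labelled ligand from sodium-dependent dopamine transporter (Rattus norvegicus), read by scintillation counting, with a stated time of 120 min (on this read-out lower numbers stand for stronger inhibition and higher numbers for weaker inhibition), compound 2 gives 115 nM. This is the largest of the three numbers measured, yet compound 1, the structure `[O-][S+](CCNC1CCN(CC(O)Cc2ccccc2)CC1)C(c1ccc(F)cc1)c1ccc(F)cc1`, gives 91.8 nM and compound 3, the structure `O=C(c1ccccc1)N1CCC(NCC[S+]([O-])C(c2ccc(F)cc2)c2ccc(F)cc2)CC1`, gives 79.1 nM, and both of these gaps to compound 2 fall within the scatter, so the three compounds cannot be told apart on these numbers.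

Compound 4, the structure `O=C(c1ccc(F)cc1F)N1CCC(NCCSC(c2ccc(F)cc2)c2ccc(F)cc2)CC1`, differs from compound 2 in one place: 2,4-difluorophenyl in place of 1-benzofuran-2-yl on a carbonyl carbon.

Among the compounds with values here, only one measured step is available, and it touches a different place: a 1.2-fold lower number from compound 1 to compound 3 (0.06 log units; within the scatter). It shows that a large swap on the ring nitrogen left the number essentially where it was. Within the data shown here, no measured step swaps one aromatic group for another on the carbonyl carbon, and compound 3, which also bears a simple benzoyl on that nitrogen, differs from compound 2 in two places, so its number can only be read alongside that of compound 2 without drawing a step.

With this, the change from compound 2 to compound 4 is expected to give a step of a 1.2-fold lower number from compound 2 to compound 4 (0.06 log units; within the scatter), that is, none beyond the scatter. Compound 4 is therefore estimated at 100 nM, with a range from 40 nM to 250 nM.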

Compound 4, inhibition constant: 30 nM
Compound 4: the middle estimate sits 3.3-fold (0.52 log units) above what was measured; the measured number lies below the stated range.
By their numbers in this assay, from the lowest: compound 4; then compounds 3, 1 and 2 (each within the scatter of the next).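

Within the data shown here, the step of a 3.8-fold lower number from compound 2 to compound 4 (0.58 log units; beyond the scatter) lies beyond the scatter in this assay, and it is the first measured step here that does so. The earlier step of a 1.2-fold lower number from compound 1 to compound 3 (0.06 log units; within the scatter) replaced the whole group on the ring nitrogen and stayed within the scatter, so it gave no sign that this part of the molecule could affect the number, whereas the new step shows that exchanging 1-benzofuran-2-yl for 2,4-difluorophenyl on a carbonyl carbon can produce a modest but real change. Nothing among the available data explains why this exchange lowers the number.

The exchange alters several things together, removing a five-membered aromatic ring and its oxygen and adding two fluorine atoms, and these two compounds alone cannot show which of these changes accounts for the step. On these data alone, it also remains open how a pyridyl ring or a naphthyl group on the same carbonyl carbon would compare, and whether the step would keep its size in compounds with a different chain on the shared core.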